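Ester variation on a shared pyrimidinone series: microsomal stability notes

This account rests on a few compounds, and the source may have more. Where it says the series, first, only, none or still open, it means among the compounds named here.

Three compounds of the series have been run in an ADME assay on microsomes from liver (Mus musculus) for metabolic stability, with a stated time of 30 min; a lower number here means that less of the compound is left, a higher number that more of the compound is left. Compound 1 `CCCCc1nc(C(C)C)c(CC(=O)OCC(C)C)c(=O)n1Cc1ccc(-c2ccccc2-c2noc(=O)[nH]2)cc1` gives 13.7%, and compound 2 `CCCCc1nc(C(C)C)c(CC(=O)OC2CCCCC2)c(=O)n1Cc1ccc(-c2ccccc2-c2noc(=O)[nH]2)cc1` gives 14.6%; the pair differ only at the ester, and a number 0.9 percentage points higher from compound 1 to compound 2 (within the scatter). Compound 3 `CCCCc1nc(C)c(CC(=O)OC)c(=O)n1Cc1ccc(-c2ccccc2-c2noc(=O)[nH]2)cc1` gives 47.1%, the highest of the three numbers, standing beyond the scatter above both compound 2 and compound 1. Within the data shown here, compound 3 differs from each of those two in two places at once, so no single-change step links it to them; only the two values themselves are known.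

Compound 4 `CCCCc1nc(C)c(CC(=O)OCC2CC2)c(=O)n1Cc1ccc(-c2ccccc2-c2noc(=O)[nH]2)cc1` carries cyclopropyl in place of hydrogen on a saturated chain carbon bound to an oxygen next to a carbonyl group. Among the measured compounds shown here, the one measured step that touches the same region is the step from compound 1 to compound 2, an exchange of one ester alkyl for another at an oxygen next to a carbonyl group, and that step stayed within the scatter. For the measured compounds named here, the change to compound 4 is smaller in added atoms than that exchange but starts from the methyl ester of compound 3, and no measured pair shows what leaving methyl for a larger ester alkyl does on its own. A step within the scatter, or a modest drop, is therefore expected in this assay; the expected step is a number 11.1 percentage points lower from compound 3 to compound 4 (beyond the scatter). For compound 4 the estimate is 36%, in the range 18% to 54%.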

Compound 4, percent of the compound remaining: 13%
Estimate against measurement, compound 4: 23 percentage points above, and the stated range ends above it.
By their numbers in this assay, from the lowest: compounds 4, 1 and 2 (each within the scatter of the next); then compound 3.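

In this assay, among these compounds, the change from methoxycarbonyl to cyclopropylmethoxycarbonyl gives a number 34.1 percentage points lower from compound 3 to compound 4 (beyond the scatter) and is the first single change to leave the methyl ester for a larger ester alkyl. Among the compounds shown here, the one earlier step at this place, a number 0.9 percentage points higher from compound 1 to compound 2 (within the scatter) and on a different core, exchanged one larger ester alkyl for another and left the question of the methyl ester untouched, whereas the new step shows that this place is not indifferent to the ester alkyl and that one change here can alone produce a large step. Nothing at hand gives a reason for the size of this step.

Still open, as far as these compounds go, is where the drop sets in between methyl and cyclopropylmethyl, and whether an ethyl ester, a longer chain on the oxygen, or the free carboxylic acid would stay close to compound 3 at 47.1% or fall away from it. For the compounds shown here, also open is how much of the separation of compound 3 from compounds 1 and 2 belongs to the ester and how much to the other place where they differ, since no single-change step links them.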